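Chain extension on the anilide of compound 2

The compounds below may be only part of what the source reports. "The series", "measured", "known", "first", "only" and "open" are said of these compounds alone.

Measured compounds:
compound 1 `CC(C)C(=O)Nc1ccc(S(=O)(=O)Oc2ccccc2C(C)C)cc1` 4900 nM
compound 2 `CC(C)c1ccccc1OS(=O)(=O)c1ccc(NC(=O)CCl)cc1` 1000 nM

Among the measured compounds shown here, compound 2 gives the lowest number of the two in a functional assay on HT-1080 cells (Homo sapiens) for antiproliferative activity, read by sulforhodamine B assay, with a stated time of 48 h; a lower number here means a stronger inhibitor, a higher number a weaker inhibitor; its only neighbour is compound 1, and the step of a 4.9-fold lower number from compound 1 to compound 2 (0.69 log units; beyond the scatter) is beyond the scatter. Compound 3 `CC(C)c1ccccc1OS(=O)(=O)c1ccc(NC(=O)CCCl)cc1` has not been measured. It differs from compound 2 by chloromethyl in place of chloro on a saturated chain carbon bound to a carbonyl carbon, so the chain on the carbonyl carbon grows by one carbon while the chlorine moves outward.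

For the measured compounds named here, only one measured step exists, a 4.9-fold lower number from compound 1 to compound 2 (0.69 log units; beyond the scatter), and it concerns the group on the carbonyl carbon, the same place that changes here; it shows that this position is sensitive to change. Going by the values given here, no measured pair tells how a longer chlorinated chain behaves. Compound 3 is therefore expected to move back toward compound 1, with a step of a 3.5-fold higher number from compound 2 to compound 3 (0.54 log units; beyond the scatter). The estimate for compound 3 in this assay is 3500 nM, ranging from 1000 nM to 12000 nM.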

Compound 3, half-maximal inhibitory concentration: 6500 nM
Estimate against measurement, compound 3: 1.9-fold (0.27 log units) below; measured number inside the range.
By their numbers in this assay, from the lowest: compound 2; then compounds 1 and 3 (each within the scatter of the next).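

In this assay the one-carbon extension gives a 6.5-fold higher number from compound 2 to compound 3 (0.81 log units; beyond the scatter) and so removes the advantage that compound 2 held at this position; a chlorine on the chain of the carbonyl carbon does not by itself keep the lower number, and its distance along the chain matters in this pair. The step of a 1.3-fold higher number from compound 1 to compound 3 (0.12 log units; within the scatter) does not separate the 2-chloroethyl group from the isopropyl group, so among these three compounds only the chloromethyl group stands apart. Nothing available here explains this difference.

The compounds shown leave open whether a bromomethyl group would behave like chloromethyl and whether a 3-chloropropyl group would stay with 2-chloroethyl. They also leave open how a plain ethyl group, without chlorine, would compare with 2-chloroethyl on the same carbonyl carbon.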